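Swapping the Piperidine for a Substituted Pyrrolidine

The source may hold more compounds than are shown below. What is called first, only, known or untested is meant among the compounds shown, and "the series" means these compounds.

Compound 1 `CN1CCN(c2ccc(Nc3ncc4nc(Nc5ccc(F)cc5)n(-c5cccc(NC(=O)CO)c5)c4n3)cc2)CC1` gives 7.5 nM in a functional assay on HCC827 cells (Homo sapiens) for antiproliferative activity, read by MTT assay, with a stated time of 72 h; on this read-out lower numbers stand for stronger inhibition and higher numbers for weaker inhibition.
Compound 2 `CN1CCN(c2ccc(Nc3ncc4nc(Nc5ccc(F)cc5)n([C@H]5CCN(C(=O)OC(C)(C)C)C5)c4n3)cc2)CC1` gives 580 nM in this assay.
Compound 3 `CN1CCN(c2ccc(Nc3ncc4nc(Nc5ccc(F)cc5)n([C@@H]5CCCNC5)c4n3)cc2)CC1` gives 120 nM in this assay.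

Compound 3 stands second highest of the three numbers, clearly weaker than compound 1 and clearly stronger than compound 2. Compound 4 `CNC(=O)CN1CC[C@H](n2c(Nc3ccc(F)cc3)nc3cnc(Nc4ccc(N5CCN(C)CC5)cc4)nc32)C1` differs from it by 1-((methylcarbamoyl)methyl)pyrrolidin-3-yl in place of piperidin-3-yl on an aromatic nitrogen. Going by the values given here, two measured steps bear on this: a 16-fold higher number from compound 1 to compound 3 (1.20 log units; beyond the scatter) and a 4.8-fold lower number from compound 2 to compound 3 (0.68 log units; beyond the scatter). Together they show that the six-membered ring with a free ring nitrogen did better than the five-membered ring carrying a carbamate. Compound 4 returns to the five-membered ring but with a different group on its nitrogen, so a modest weakening is expected, a 1.8-fold higher number from compound 3 to compound 4 (0.26 log units; within the scatter). Compound 4 is therefore estimated at 220 nM, with a likely range from 60 nM to 800 nM.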

Compound 4, half-maximal inhibitory concentration: 1520 nM
For compound 4 the middle estimate is 6.9-fold (0.84 log units) below the measured one; the measured number lies above the stated range.
By their numbers in this assay, from the lowest: compound 1; then compound 3; then compound 2; then compound 4.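

On the pyrrolidine nitrogen, (methylcarbamoyl)methyl does worse than tert-butoxycarbonyl, with a 2.6-fold higher number from compound 2 to compound 4 (0.42 log units; beyond the scatter), so the group on this ring nitrogen matters even when the five-membered ring stays the same. Replacing piperidin-3-yl with the whole new group brings a larger loss, with a 13-fold higher number from compound 3 to compound 4 (1.10 log units; beyond the scatter), and the gap to the 3-(((hydroxymethyl)carbonyl)amino)phenyl group grows to a 200-fold higher number from compound 1 to compound 4 (2.31 log units; beyond the scatter). Nothing measured here gives a reason for these losses.

An unsubstituted pyrrolidin-3-yl, or a piperidine carrying (methylcarbamoyl)methyl, would help separate the effect of ring size from that of the nitrogen group. Going by these compounds, how a carboxylic acid or a longer chain on that nitrogen would behave remains open.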